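The source may report more compounds than this note shows. Statements on the series, on what has been measured and on what is new or still open speak of the compounds shown alone.

Measured compounds in a functional assay on BJAB cells (Homo sapiens) for antiproliferative activity, with a stated time of 4 days; a lower number here means that less compound is needed, a higher number that more compound is needed for the effect:
- compound 1, `Cc1c(-c2cc(Cl)cc(Cl)c2)c(C(=O)O)nn1-c1nc(-c2cc(Cl)ccc2F)c(SC(C)C)s1`: 4800 nM
- compound 2, `Cc1nn(-c2nc(-c3ccc(Cl)c(Cl)c3)c(SC(C)C)s2)c(C(=O)O)c1-c1cnn(C)c1`: 6800 nM
- compound 3, `Cc1nn(-c2nc(-c3ccc(Cl)c(Cl)c3)c(SC(C)C)s2)c(C(=O)O)c1-c1cccc(Cl)c1C`: 5100 nM

All three numbers sit close together. Compound 1 gives the lowest of the three, but its gaps to compound 3 and to compound 2 are both within the scatter, so no order among them can be read from these data.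

For the measured compounds named here, the one step that can be traced between measured compounds is a 1.3-fold lower number from compound 2 to compound 3 (0.12 log units; within the scatter), a change on the group attached to the shared core, not on the thiazole-bound aryl group.

Compound 4, `Cc1oncc1-c1nc(-n2nc(C(=O)O)c(-c3cc(Cl)cc(Cl)c3)c2C)sc1SC(C)C`, is not yet measured. It differs from compound 1 in one place: 5-methyl-1,2-oxazol-4-yl in place of 5-chloro-2-fluorophenyl on an aromatic carbon. Going by the values given here, this change sits at a position that none of the measured steps touches; the change from compound 2 to compound 3 concerns a different attachment point and stays within the scatter, so it gives no direct guide for the size or direction here. Among the compounds with values here, with the three measured values lying within one band and no step at this position, the working expectation is that compound 4 stays near compound 1, with a step of a 1.3-fold higher number from compound 1 to compound 4 (0.10 log units; within the scatter) not expected to exceed the scatter, though the range must be set wide. Compound 4 is estimated at 6000 nM, between 2500 nM and 15000 nM.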

Compound 4, half-maximal effective concentration: > 44000 nM
Compound 4: only a limit was reported (the forecaster's own chance of this, stated with the estimate: 10%); at least 7.3-fold (0.86 log units) between middle value and limit.
By their numbers in this assay, from the lowest: compounds 1, 3 and 2 (each within the scatter of the next). At a limit, above all of these: compound 4.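

In this assay, for the compounds shown here, 5-methyl-1,2-oxazol-4-yl in place of 5-chloro-2-fluorophenyl, on the aromatic carbon next to the ring nitrogen, gives an at least 9.1-fold higher number from compound 1 to compound 4 (0.96 log units; beyond the scatter), the first step in this set that lies beyond the scatter. The figure for compound 4 is a limit of the assay and not a number: the limit of > 44000 nM in this assay, at which 1 of the 4 values shown sits.

Going by these compounds alone, the earlier compounds sat in one narrow band, and the only step among them, a 1.3-fold lower number from compound 2 to compound 3 (0.12 log units; within the scatter), concerns a different attachment point and stays within the scatter, whereas this position proves sensitive to the group it carries.

A single replacement at this position cannot separate the removal of the chlorine and fluorine from the change from a six-membered carbon ring to a five-membered ring with two hetero atoms. As far as these compounds go, whether a plain phenyl, a pyridine ring or an amine on this carbon would bring the number back towards that of compound 1 remains open, as does the true size of the step, which the limit leaves unfixed.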